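Cytotoxicity notes on the methylenecyclopropane purine series

A few compounds are considered here, and "the series" means these few. Any claim that something is new, unique, unknown or untested is made for them only; others in the source may bear on it.

Measured so far:
Compound 1 `CCCNc1nc(N)nc2c1ncn2/C=C1/CC1(CO)CO` in an ADME assay on BCBL1 cells (Homo sapiens) for cytotoxicity, with a stated time of 7 days (on this read-out higher numbers stand for lower toxicity in this test and lower numbers for higher toxicity in this test), gives > 20000 nM, a limit of the test.
Compound 2 `CCCCCCCCSc1nc(N)nc2c1ncn2/C=C1/CC1(CO)CO` in this assay gives > 20000 nM, likewise a limit.
Compound 3 `Nc1nc(NC2CCCCC2)c2ncn(/C=C3/CC3(CO)CO)c2n1` in this assay gives > 20000 nM, again only a limit.

Compound 3 therefore stands where every compound of the set stands so far, at the upper edge of what this assay reports; the three results share (the limit of > 20000 nM in this assay, at which 3 of the 3 values shown sit).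

The step now considered goes from compound 3 to compound 4 `CCCCSc1nc(N)nc2c1ncn2/C=C1/CC1(CO)CO` by butylsulfanyl in place of cyclohexylamino on an aromatic carbon.

Which measured steps bear on it: a step that the two limits leave unreadable from compound 2 to compound 3 runs the same exchange the other way, a cyclohexylamino for an octylsulfanyl; a step that the two limits leave unreadable from compound 1 to compound 2 and a step that the two limits leave unreadable from compound 1 to compound 3 trade between amino-linked and sulfur-linked side chains on the same carbon. All three steps are unreadable, since both ends sit at the limit, so no direction and no size can be taken from them for the change toward a butylsulfanyl.

With nothing pointing toward higher toxicity, compound 4 is expected in this assay to give about 20000 nM, with a range from 10000 nM to 40000 nM, so that a number no higher from compound 3 to compound 4 (the limit leaves the size open) is the expected step, and a result again reported only as a limit is the most probable outcome.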

Compound 4, half-maximal cytotoxic concentration: > 20000 nM
Compound 4 was reported as a limit; the forecaster's own chance of this, stated with the estimate: 80%; the middle value sits exactly at the limit.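

Compound 4 in this assay gives > 20000 nM, again a limit. None of the steps from compound 1, compound 2 or compound 3 to compound 4 can be read, so the result yields no new step: the limit of > 20000 nM in this assay, at which 4 of the 4 values shown sit.

The compounds shown leave open whether any of these side chains on the aromatic carbon gives a readable half-maximal cytotoxic concentration.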